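A Pyrrolidine Ring in Place of an Ethylamino Group

The source may report more compounds than this note shows. Statements on the series, on what has been measured and on what is new or still open speak of the compounds shown alone.

Compound 1, `CCCCNC(=O)Nc1cccc2c1CN(C)CC2c1ccc(Cl)cc1`, gives about 120 mg/kg in a functional assay on the whole organism for inhibition of sodium-dependent dopamine transporter (Mus musculus); on this read-out lower numbers stand for an effect already at smaller amounts and higher numbers for an effect only at larger amounts of compound. Compound 2, `CCOC(=O)Nc1cccc2c1CN(C)CC2c1ccc(Cl)cc1`, gives 21 mg/kg. Compound 3, `CCNCC(=O)Nc1cccc2c1CN(C)CC2c1ccccc1`, gives about 60 mg/kg.

Among the three numbers in this assay, compound 3 stands second highest. Compound 1 lies within the scatter of compound 3, so no order between them can be read; compound 2 lies beyond the scatter, with the lower number of the two. Compound 4, `CN1Cc2c(NC(=O)CN3CCCC3)cccc2C(c2ccccc2)C1`, differs from compound 3 in one place: pyrrolidin-1-yl in place of ethylamino on a saturated chain carbon bound to a carbonyl carbon. The only measured step among these compounds, a 5.7-fold lower number from compound 1 to compound 2 (0.76 log units; beyond the scatter), concerns the group on the carbonyl carbon itself, not the saturated chain carbon bound to it, so it does not bear directly on this change. Among the compounds with values here, no measured pair shows what replacing an open-chain amine by a ring amine at that position does in this assay. On the numbers available, compound 4 is therefore expected to stay close to compound 3, and the expected step of no change at the digits printed from compound 3 to compound 4 (within the scatter) is none beyond the scatter, in either direction. Compound 4 is estimated at 60 mg/kg, with a range from 25 mg/kg to 150 mg/kg.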

Compound 4, dose for half-maximal effect: 45 mg/kg
For compound 4 the middle estimate is 1.3-fold (0.12 log units) above the measured one; low and high end bracket the measured number.
By their numbers in this assay, from the lowest: compound 2; then compounds 4, 3 and 1 (each within the scatter of the next, the first and the last beyond it).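

Within the data shown here, the exchange of ethylamino for pyrrolidin-1-yl on a saturated chain carbon bound to a carbonyl carbon gives a 1.3-fold lower number from compound 3 to compound 4 (0.12 log units; within the scatter) in this assay, the first measured step at this position. So the read-out does not separate the open-chain amine from the ring amine, although the entering group brings a five-membered non-aromatic ring, has more heavy atoms and has no hydrogen-bond donor. This holds for this one pair only, and no measurement at hand bears on why the two numbers stay together.

The compounds shown leave open whether a piperidine ring, a morpholine ring or a dimethylamino group at the same place would stay within the scatter of these two compounds, and whether a longer chain between the carbonyl carbon and the amine would do so too. They also leave open what a chlorine on the phenyl ring of compound 4 would do to the number in this assay.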